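From Ethylsulfamoyl to Ethylcarbamoyl: Compound 3 to Compound 4

This account rests on a few compounds, and the source may have more. Where it says the series, first, only, none or still open, it means among the compounds named here.

Three biaryl esters and related compounds have been tested in an assay on COS-7 cells for inhibition of patatin-like phospholipase domain-containing protein 2 (Mus musculus), tested at 200 uM; on this read-out higher numbers stand for more inhibition at the one concentration tested (going by the name of the read-out) and lower numbers for less inhibition. Compound 1 `CCOC(=O)c1cccc(-c2ccc(N(C)C)cc2)c1` gives 87%, compound 2 `CCOC(=O)c1cccc(-c2ccncc2)c1` gives 40%, and compound 3 `CCNS(=O)(=O)c1cccc(-c2ccc(OCC)cc2)c1` gives 46%. Among these three numbers compound 3 stands second highest: its nearest neighbour is compound 2, whose value lies within the usual scatter of compound 3, while compound 1 lies beyond the scatter on the higher side.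

Compound 4 `CCNC(=O)c1cccc(-c2ccc(OCC)cc2)c1` has not yet been measured. Compared with compound 3, it carries ethylcarbamoyl in place of ethylsulfamoyl on an aromatic carbon. Among the measured compounds shown here, no measured pair in this set shows the same change, so the size of the step from compound 3 to compound 4 in this assay is uncertain. Given that the shared core with a para ethoxy substituent on the second ring is retained, the expected step of a number 1 percentage points lower from compound 3 to compound 4 (within the scatter) is small, and no change beyond the scatter is expected. Compound 4 is therefore estimated at 45%, with a range from 20% to 70%.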

Compound 4, a percentage reported as inhibition, at one concentration (the size of the read-out at that concentration, not a potency): 62%
Beside the measured number, compound 4's estimate is 17 percentage points below it; low and high end bracket the measured number.
By their numbers in this assay, from the lowest: compounds 2 and 3 (each within the scatter of the next); then compound 4; then compound 1.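

Among the compounds shown here, this is the first pair in the set that differs in one place only, and it shows that the group on this aromatic carbon matters in this assay: ethylcarbamoyl in place of ethylsulfamoyl gives a number 16 percentage points higher from compound 3 to compound 4 (beyond the scatter). Both groups carry the same ethyl chain on nitrogen, so the step comes from exchanging the sulfonyl part for a carbonyl, although a single pair shows this only on this core. Nothing measured here explains why the carbonyl version gives the higher number.

On these data alone, whether the same exchange would give a similar step with another group on the second ring, such as the dimethylamino group of compound 1, remains open. Also open, as far as these compounds go, is how a carboxylic acid, or a propyl chain on the amide nitrogen, would read at this position.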